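This account rests on a few compounds, and the source may have more. Where it says the series, first, only, none or still open, it means among the compounds named here.

Working notes on the cytotoxicity series.

Three compounds carry the shared core with a diyne-linked terminal group. Compound 1 `CCCc1ccc(C#CC#Cc2cn([C@H]3C[C@H](O)[C@@H](CO)O3)c(=O)[nH]c2=O)cc1` gives 52000 nM in an ADME assay on HEL cells (Homo sapiens), read by cell counting, with a stated time of 3 days; on this read-out higher numbers stand for lower toxicity in this test and lower numbers for higher toxicity in this test. Compound 2 `O=c1[nH]c(=O)n([C@H]2C[C@H](O)[C@@H](CO)O2)cc1C#CC#Cc1ccccn1` gives 1500 nM in this assay. Compound 3 `Cc1cc(C#CC#Cc2cn([C@H]3C[C@H](O)[C@@H](CO)O3)c(=O)[nH]c2=O)ccc1F` gives 45000 nM in this assay. On these numbers compound 3 stands second highest of the three: its nearest neighbour is compound 1, with a 1.2-fold lower number from compound 1 to compound 3 (0.06 log units; within the scatter), and its furthest is compound 2, with a 30-fold higher number from compound 2 to compound 3 (1.48 log units; beyond the scatter).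

The next step is cyclopropyl in place of 4-fluoro-3-methylphenyl on a triple-bonded carbon, giving compound 4 `O=c1[nH]c(=O)n([C@H]2C[C@H](O)[C@@H](CO)O2)cc1C#CC#CC1CC1`. Among the measured compounds shown here, no measured step exchanges an aromatic ring for a non-aromatic one here. For the measured compounds named here, the only aromatic-for-aromatic swap, a 1.2-fold lower number from compound 1 to compound 3 (0.06 log units; within the scatter), sat within the scatter, while the swap to pyridin-2-yl, a 35-fold lower number from compound 1 to compound 2 (1.54 log units; beyond the scatter), was large. Neither bears directly on cyclopropyl, so the expected step of a 1.3-fold higher number from compound 3 to compound 4 (0.12 log units; within the scatter) is small and of uncertain direction, most likely not beyond the scatter. Compound 4 is therefore expected near 60000 nM in this assay, with a range of 20000 nM to 180000 nM.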

Compound 4, half-maximal cytotoxic concentration: > 100000 nM
Compound 4 gave a limit, no number; the forecaster's own chance of this, stated with the estimate: 25%; at least 1.6-fold (0.22 log units) between middle value and limit.
By their numbers in this assay, from the lowest: compound 2; then compounds 3 and 1 (each within the scatter of the next). At a limit, above all of these: compound 4.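

In this assay compound 4 gives a limit, not a number: the limit of > 100000 nM in this assay, at which 1 of the 4 values shown sits. Compound 4 carries the only non-aromatic ring of the series on the triple-bonded carbon, and an aromatic ring proves unnecessary there for a high number, with an at least 2.2-fold higher number from compound 3 to compound 4 (0.34 log units; beyond the scatter) and an at least 66-fold higher number from compound 2 to compound 4 (1.82 log units; beyond the scatter). Among the compounds shown here, the remaining step, an at least 1.9-fold higher number from compound 1 to compound 4 (0.28 log units; that floor lies within the scatter), leaves those two compounds unseparated, so compound 2 with its pyridin-2-yl remains the only clear low number.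

The limit leaves open how far the true value of compound 4 lies from the others. Going by these compounds, it is also open whether an open-chain group such as tert-butyl, a larger ring such as cyclohexyl, or a pyridin-3-yl or aminomethyl group at this place would follow compound 4 or compound 2.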